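The source may hold more compounds than are shown below. What is called first, only, known or untested is meant among the compounds shown, and "the series" means these compounds.

Compound 1 `COCCOc1cc(/C=C/c2ccc3ccccc3c2)ccc1OC`: > 5000 nM (a limit)
Compound 2 `COCCOc1cc(/C=C\c2ccc3ccccc3c2)ccc1OC`: 2990 nM
Compound 3 `CC(=O)Oc1ccc(/C=C/c2ccc3ccccc3c2)cc1`: > 5000 nM (a limit)

In a functional assay on HT-29 cells (Homo sapiens) for inhibition (a lower number here means a stronger inhibitor, a higher number a weaker inhibitor), compound 1 has no number, only (the limit of > 5000 nM in this assay, at which 2 of the 3 values shown sit). Compound 3 is the other compound held at that limit, so any step starting from compound 1 starts from a limit and not from a measured value.

Compound 4 `COc1ccc(/C=C/c2ccc3ccccc3c2)cc1F` is reached from compound 1 by one change, fluoro in place of 2-methoxyethoxy on an aromatic carbon, ortho to a methoxy group and meta to a large group. The double bond stays drawn E.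

Among the compounds with values here, the one measured step is an at least 1.6-fold lower number from compound 1 to compound 2 (0.22 log units; that floor lies within the scatter), and it bears on this change only indirectly, given (the fact that compounds 1 and 2 differ only in the configuration as drawn). Within the data shown here, no measured step replaces 2-methoxyethoxy, so the data give no size for this swap. Compound 4 keeps the E configuration of compound 1, and compound 3, also drawn E, gives > 5000 nM, which is a limit. On that basis, no step beyond the scatter is expected in this assay, and a further limit is the likeliest report.

The step is estimated as a step that the limit leaves unreadable from compound 1 to compound 4. For compound 4 the expected value is 6000 nM, with an estimated range from 2500 nM to 15000 nM.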

Compound 4, half-maximal inhibitory concentration: > 5000 nM
Compound 4 gave a limit, no number; the forecaster's own chance of this, stated with the estimate: 70%; the middle value does not contradict the limit.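

In this assay compound 4 gives > 5000 nM, which is a limit. Within the data shown here, compound 1 also sits at a limit, so no step between compound 1 and compound 4 can be read. The compounds shown leave open how far fluoro in place of 2-methoxyethoxy moves the number in this assay, on either the E-drawn or the Z-drawn double bond.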